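The compounds below may be only part of what the source reports. "The series", "measured", "known", "first", "only" and "open" are said of these compounds alone.

Going by the values given here, compound 3 `S=C(Nc1ccc(Br)cc1)Nc1ccc2[nH]ccc2c1` gives 5900 nM in an ADME assay on cells for inhibition of Amine oxidase [flavin-containing] A (Homo sapiens), read by spectrophotometry (a lower number here means a stronger inhibitor, a higher number a weaker inhibitor), and is the only compound here with a number. Compound 1 `S=C(Nc1ccccc1)Nc1ccc2[nH]ccc2c1` reaches only a limit of the assay, > 30000 nM. Compound 2 `Oc1cccc(NC(=S)Nc2ccc3[nH]ccc3c2)c1` is reported as "not active" (no number reported), without a number. The change from compound 3 to compound 4 `CC(=O)Nc1ccc(NC(=S)Nc2ccc3[nH]ccc3c2)cc1` is acetamido in place of bromo on an aromatic carbon. Among the compounds with values here, the one measured step, an at least 5.0-fold lower number from compound 1 to compound 3 (0.70 log units; beyond the scatter), bears on it only indirectly: it shows that bromo in place of hydrogen gave a lower number, and compound 4 gives that bromo up again. Compound 2, the other analog that replaces that hydrogen, shows no activity. A step back toward weaker inhibition, a 3.4-fold higher number from compound 3 to compound 4 (0.53 log units; beyond the scatter), is therefore expected. Compound 4 is estimated at 20000 nM, with a range from 5000 nM to 60000 nM.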

Compound 4, half-maximal inhibitory concentration: 71000 nM
Compound 4: the middle estimate sits 3.6-fold (0.55 log units) below what was measured; the whole stated range lies below it.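

On this aromatic carbon, para to a large group, the choice of group matters a great deal: acetamido in place of bromo gives a 12-fold higher number from compound 3 to compound 4 (1.08 log units; beyond the scatter). The activity of compound 3 therefore does not survive this swap. The step from compound 1 to compound 4 cannot be read, as compound 1 stands at a limit: the limit of > 30000 nM in this assay, at which 1 of the 4 values shown sits.

Going by these compounds, it remains open how chloro or an amine at this place would compare with bromo. Also open, on these data alone, is whether the loss follows from acetamido's added heavy atoms or its hydrogen-bond donor and acceptor.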